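This account rests on a few compounds, and the source may have more. Where it says the series, first, only, none or still open, it means among the compounds named here.

Working notes on the series, all read in a functional assay on PC-3 cells (Homo sapiens) for antiproliferative activity, read by MTT assay, with a stated time of 48 h; a higher number here means a weaker inhibitor, a lower number a stronger inhibitor. Compound 1 (`C#Cc1cccc(Nc2ncnc3cc(NC(=O)/C=C/c4ccccc4)sc23)c1`) gives 700 nM, compound 2 (`COc1ccc(/C=C/C(=O)Nc2cc3c(Nc4ccc(Cl)c(Cl)c4)ncnc3s2)cc1`) gives 790 nM, and compound 3 (`O=C(/C=C/c1ccccc1)Nc1cc2c(Nc3ccc(F)c(Cl)c3)ncnc2s1`) gives 700 nM. Compound 3 stands level with compound 1, and all three values lie within the scatter of one another, so they show no order.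

Compound 4 (`O=C(/C=C/c1ccccc1)Nc1cc2c(Nc3cccc(Cl)c3F)ncnc2s1`) has not yet been measured. It has the same atoms as compound 3, joined differently: 3-chloro-2-fluorophenyl in place of 3-chloro-4-fluorophenyl on a nitrogen on an aromatic ring. The change is 3-chloro-2-fluorophenyl in place of 3-chloro-4-fluorophenyl on a nitrogen on an aromatic ring.

Among the compounds with values here, no measured pair differs in one place only, so no direct comparison exists for this change. Within the data shown here, the only guide is the narrow spread of the measured compounds, with compound 2 at 790 nM and compound 3 at 700 nM. No step beyond the scatter is therefore expected. The estimated 1.1-fold higher number from compound 3 to compound 4 (0.06 log units; within the scatter) stays within the scatter. For compound 4 the estimated value is 800 nM, with an expected range of 300 nM to 2200 nM.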

Compound 4, half-maximal inhibitory concentration: 400 nM
Compound 4: the middle estimate sits 2.0-fold (0.30 log units) above what was measured, within the range that was stated.
By their numbers in this assay, from the lowest: compounds 4, 1, 3 and 2 (each within the scatter of the next).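

In this assay, within the data shown here, 3-chloro-2-fluorophenyl in place of 3-chloro-4-fluorophenyl on a nitrogen on an aromatic ring gives a 1.8-fold lower number from compound 3 to compound 4 (0.24 log units; within the scatter) and provides the first direct comparison at this place. For this pair, the same atoms joined differently do not give a step beyond the scatter, so the two groups cannot be told apart in this read-out. No measurement available here bears on the result.

Going by these compounds, it remains open whether a group of another kind on that nitrogen, such as a phenyl ring carrying a carboxylic acid or an amine, would give a step beyond the scatter. On these data alone, it is also open whether the same change would read alike in a compound carrying the methoxy group of compound 2.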